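The compounds below may be only part of what the source reports. "The series", "measured", "known", "first", "only" and "open" are said of these compounds alone.

Of the compounds shown here, three have been measured in an ADME assay on cells (Splenocyte, Mus musculus, strain BALB/c) for cytotoxicity, read by MTT assay, tested at 10 ug/mL; a higher number here means a stronger effect of the compound at the concentration tested, a lower number a weaker effect. Compound 1 `CCCCCCCCCCCCCCC(NC(=O)OC(C)(C)C)C(=O)O` gives 5.1%, compound 2 `CCCCCCCCCCCCCCC(CO)NCCCC` gives 16.4%, and compound 3 `CCCCCCCCCCCCCCC(C(=O)O)N(CC)CC` gives 12.1%. Within the data shown here, the one step between measured compounds that differ in a single place, a number 7 percentage points higher from compound 1 to compound 3 (within the scatter), was within the scatter, and compound 3 stands with compound 2 and compound 1 both within the scatter of its own number. Compound 4 `CCCCCCCCCCCCCCC(NCCCC)C(=O)O` is the next compound to be tested. Among the measured compounds shown here, the change, (butylamino in place of diethylamino on a saturated chain carbon bound to a carbonyl carbon and a saturated chain carbon), is matched by no measured step; its only echo is the butylamino group of compound 2, whose number in this assay is within the scatter of compound 3. A small step is therefore expected, a number 1.9 percentage points higher from compound 3 to compound 4 (within the scatter), with no direction beyond the scatter. Compound 4 is expected to give 14%, within a range from 4% to 26%.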

Compound 4, a percentage reported as activity, at one concentration (the size of the read-out at that concentration, not a potency): 5.1%
Compound 4: middle estimate off by 8.9 percentage points, on the high side; the measured number falls inside the stated range.
By their numbers in this assay, from the lowest: compounds 1, 4, 3 and 2 (each within the scatter of the next, the first and the last beyond it).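

In this assay, among these compounds, the result gives a number 11.3 percentage points lower from compound 2 to compound 4 (beyond the scatter) with carboxy in place of hydroxymethyl, the first step here beyond the scatter. Against this stand a number 7 percentage points lower from compound 3 to compound 4 (within the scatter) and no change at the digits printed from compound 1 to compound 4 (within the scatter), so neither butylamino in place of diethylamino nor butyl in place of tert-butoxycarbonyl on an amine nitrogen separates these compounds. Nothing available explains the step from compound 2 to compound 4. Open, going by these compounds, is whether carboxy in place of hydroxymethyl gives a similar step with diethylamino as the amine or with a shorter or longer chain. On these data alone, a methyl ester in place of carboxy also remains open.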